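Hydroxymethyl on the core: expected half-life for compound 3

The compounds below may be only part of what the source reports. "The series", "measured", "known", "first", "only" and "open" are said of these compounds alone.

Measured compounds:
compound 1 `CCCCN(c1nc2ccccc2o1)[C@H](C)c1ccc(-c2ccccc2-c2nnn[nH]2)cc1`: 3.2 h
compound 2 `C[C@H](c1ccc(-c2ccccc2-c2nc(=O)o[nH]2)cc1)N(CC1CC1)c1nc2c(C(=O)O)cccc2o1`: 2.6 h

Two compounds have been characterised in an ADME assay on the whole organism (Macaca fascicularis) for metabolic stability, read by LC-MS, using cassette dosing, at a dose of 1 mg/kg by the oral route; a lower number here means that the compound disappears faster, a higher number that the compound lasts longer. Compound 1 gives 3.2 h, the higher of the two numbers, while compound 2 gives 2.6 h; the two values lie within the scatter of each other, so neither can be ranked over the other. Compound 2 differs from compound 1 in several places at once, so the pair yields no single-point comparison.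

Compound 3 `CCCCN(c1nc2c(CO)cccc2o1)[C@H](C)c1ccc(-c2ccccc2-c2nnn[nH]2)cc1` is the compound next in line and has not yet been measured. It differs from compound 1 by hydroxymethyl in place of hydrogen on an aromatic carbon. Among the compounds with values here, no measured pair shows this change, so the expectation rests on compound 1 alone. The step from compound 1 to compound 3 in this assay is expected to be small, at most a modest shortening and possibly nothing beyond the scatter, a 1.3-fold lower number from compound 1 to compound 3 (0.12 log units; within the scatter). Compound 3 is therefore estimated at 2.4 h, with a plausible range from 1.2 h to 4.8 h.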

Compound 3, half-life: 1.6 h
Beside the measured number, compound 3's estimate is 1.5-fold (0.18 log units) above it; the measured number falls inside the stated range.
By their numbers in this assay, from the lowest: compounds 3, 2 and 1 (each within the scatter of the next).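

In this assay, replacing hydrogen with hydroxymethyl on an aromatic carbon of the six-membered ring of the shared core, which turns 1,3-benzoxazol-2-yl into 4-(hydroxymethyl)-1,3-benzoxazol-2-yl, gives a 2.0-fold lower number from compound 1 to compound 3 (0.30 log units; within the scatter). Within the data shown here, this is the first comparison that isolates a single place, and on this one pair the effect of the change cannot be told apart from the spread of repeated measurements. Nothing measured on these compounds offers an explanation for the step.

On these data alone, it remains open whether an aminomethyl or methoxymethyl group at this position would give a step beyond the scatter. It is also unknown whether hydroxymethyl would give a similar step on another aromatic carbon of this ring or with a chain other than butyl on the nitrogen.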